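The source may hold more compounds than are shown below. What is called first, only, known or untested is meant among the compounds shown, and "the series" means these compounds.

Of the compounds shown here, three of a shared core have been measured in a functional assay on DU-145 cells (Homo sapiens) for antiproliferative activity, read by MTT assay, with a stated time of 24 h; on this read-out lower numbers stand for stronger inhibition and higher numbers for weaker inhibition. Compound 1 `COc1ccc(C(=O)/C=C/c2cc(-c3cc(OC)c(OC)c(OC)c3)n3nc(-c4ccccc4)cc3n2)cc1OC` gives 29900 nM, compound 2 `COc1ccc(C(=O)/C=C/c2cc(-c3ccc(OC)c(OC)c3)n3nc(-c4ccccc4)cc3n2)cc1` gives 14600 nM, and compound 3 `COc1cc(-c2cc(/C=C/C(=O)c3ccc(C)cc3)nc3cc(-c4ccccc4)nn23)cc(OC)c1OC` gives 27100 nM. Compound 2 therefore gives the lowest number of the three; its nearest neighbour is compound 3, within the scatter, while compound 1 lies beyond it. Going by the values given here, the one step between measured compounds, a 1.1-fold lower number from compound 1 to compound 3 (0.04 log units; within the scatter), also falls on the carbonyl carbon and was within the scatter.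

Compound 4 `COc1ccc(-c2cc(/C=C/C(=O)c3ccc(C)c(C)c3)nc3cc(-c4ccccc4)nn23)cc1OC` is not yet measured. It differs from compound 2 in one place: 3,4-dimethylphenyl in place of 4-methoxyphenyl on a carbonyl carbon. Among the compounds with values here, the only comparable step, that from compound 1 to compound 3, exchanged groups on the same carbonyl carbon without moving the number beyond the scatter, so an exchange of the group on the carbonyl carbon here is also expected to leave the value near that of compound 2, with a step of a 1.1-fold higher number from compound 2 to compound 4 (0.04 log units; within the scatter) expected in this assay. Compound 4 is accordingly estimated at 16000 nM, with a range from 7000 nM to 36000 nM.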

Compound 4, half-maximal inhibitory concentration: 12100 nM
For compound 4 the middle estimate is 1.3-fold (0.12 log units) above the measured one, and the stated range covers the measured number.
By their numbers in this assay, from the lowest: compounds 4, 2, 3 and 1 (each within the scatter of the next, the first and the last beyond it).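

In this assay the exchange of 4-methoxyphenyl for 3,4-dimethylphenyl on the carbonyl carbon gives a 1.2-fold lower number from compound 2 to compound 4 (0.08 log units; within the scatter) and so stays within the scatter. The earlier step of a 1.1-fold lower number from compound 1 to compound 3 (0.04 log units; within the scatter) was also within the scatter, but compound 2 and compound 4 differ from that pair elsewhere in the structure, so the same small result now holds for a second pair of compounds. It also holds for an exchange in which the group with a hydrogen-bond acceptor leaves and a group with none enters, with no oxygen left on this group.

Going by these compounds, the groups on this carbonyl carbon are all phenyl rings bearing methyl or methoxy, so whether an amine or a carboxylic acid on that ring, or a longer chain in its place, would shift the number beyond the scatter remains open. No measurement shown bears on why these exchanges leave the number so little changed.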